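One small group swapped, from trifluoromethoxy to chloro

The source may report more compounds than this note shows. Statements on the series, on what has been measured and on what is new or still open speak of the compounds shown alone.

In an ADME assay on HEK293 cells (Homo sapiens) for cytotoxicity, with a stated time of 72 h (a higher number here means that more compound is needed for the effect, a lower number that less compound is needed), compound 1 `Cc1cc(NC(=O)Nc2ccc(N)cc2)c2ccccc2n1` gives > 25000 nM, which is a limit of the assay and not a number. Going by the values given here, compound 2 `Cc1cc(NC(=O)Nc2cccc(OC(F)(F)F)c2)c2ccccc2n1` gives 22000 nM, the only exact number so far, so it cannot yet be ranked against another exact value. Compound 3 `Cc1cc(NC(=O)Nc2cccc(Cl)c2)c2ccccc2n1` differs from it by one group: chloro in place of trifluoromethoxy on an aromatic carbon. That is chloro in place of trifluoromethoxy on an aromatic carbon. Among the compounds with values here, with no measured step to guide this change, no shift beyond the usual scatter is expected, and the estimated step is a 1.1-fold lower number from compound 2 to compound 3 (0.04 log units; within the scatter). Compound 3 is expected at 20000 nM, with an estimated range of 9000 nM to 25000 nM.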

Compound 3, half-maximal effective concentration: 21000 nM
Estimate against measurement, compound 3: 1.1-fold (0.02 log units) below; the range from low to high includes it.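

In this assay, the swap gives a 1.0-fold lower number from compound 2 to compound 3 (0.02 log units; within the scatter), so at this position on the aromatic ring, chloro and trifluoromethoxy read alike even though chloro has fewer heavy atoms. Compound 1 gives only a limit of the assay, not a number: the limit of > 25000 nM in this assay, at which 1 of the 3 values shown sits. Its step is an at least 1.1-fold lower number from compound 1 to compound 3 (0.07 log units; that floor lies within the scatter), which is a floor and not a measured size.

Going by these compounds, whether a carboxylic acid or a longer alkoxy chain at this position would shift the number beyond the scatter stays open. So does the effect of changes to the shared core.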